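The compounds below may be only part of what the source reports. "The series", "measured", "known", "first", "only" and "open" are said of these compounds alone.

Measured compounds:
compound 1 `COc1cc(NC(C)CCCNC(=O)Nc2cccc(Cl)c2)c2ncccc2c1`, 26000 nM
compound 2 `COc1cc(NC(C)CCCNC(=O)Nc2ccc(Br)cc2)c2ncccc2c1`, 23000 nM
compound 3 `COc1cc(NC(C)CCCNC(=O)Nc2ccc(F)cc2)c2ncccc2c1`, 25000 nM

All three were run in a functional assay on SW-620 cells (Homo sapiens) for inhibition, read by MTT assay, with a stated time of 72 h; a higher number here means a weaker inhibitor, a lower number a stronger inhibitor. Compound 1 gives the topmost of the three numbers, but its distance to either neighbour is small: a 1.0-fold lower number from compound 1 to compound 3 (0.02 log units; within the scatter) and a 1.1-fold lower number from compound 1 to compound 2 (0.05 log units; within the scatter), both inside the scatter of repeat measurements. The step of a 1.1-fold higher number from compound 2 to compound 3 (0.04 log units; within the scatter) is likewise flat. Within this small set, exchanging one halogen on the phenyl ring for another, or moving it, leaves the read-out essentially unchanged.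

Compound 4 `COc1cc(NC(C)CCCNC(=O)Nc2cccc(O)c2)c2ncccc2c1` is the next analogue of compound 1. The change is hydroxy in place of chloro on an aromatic carbon. Within the data shown here, none of the measured steps involves a hydroxy group; the three measured steps only show that the phenyl substituent can be varied among halogens without moving the number in this assay. That evidence bears on compound 4 only loosely, since a hydroxy group is a different kind of substituent from a halogen, and nothing in the series tests a hydrogen-bond donor at that position.

The expectation for compound 4 is therefore a number close to compound 1, with no step beyond the scatter, a 1.2-fold higher number from compound 1 to compound 4 (0.06 log units; within the scatter). The estimate for compound 4 in this assay is 30000 nM, with a range of 14000 nM to 65000 nM to allow for the untested nature of the substituent.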

Compound 4, half-maximal inhibitory concentration: 27000 nM
Compound 4: middle estimate off by 1.1-fold (0.05 log units), on the high side; the measured number falls inside the stated range.
By their numbers in this assay, from the lowest: compounds 2, 3, 1 and 4 (each within the scatter of the next).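

In this assay, hydroxy in place of chloro on this aromatic carbon, meta to a large group, gives a 1.0-fold higher number from compound 1 to compound 4 (0.02 log units; within the scatter), so the first substituent in the series that is not a halogen, and the first to bring a hydrogen-bond donor and acceptor, leaves the read-out flat. The 3-hydroxyphenyl compound also stays level with the 4-halophenyl analogues, at a 1.1-fold higher number from compound 3 to compound 4 (0.03 log units; within the scatter) and a 1.2-fold higher number from compound 2 to compound 4 (0.07 log units; within the scatter), so the flat range now extends from the three halogen-bearing phenyl rings to the 3-hydroxyphenyl ring. The data shown offer nothing that accounts for this flat response.

Still open, on these data alone, is whether an amine, a carboxylic acid or a methoxy group on the same aromatic carbon would also leave the number in place. All four compounds share the core and its chain, so the effect of a shorter or longer chain, or of a different group in place of the methoxy on the core, remains an open question for this series.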